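Nitro for Fluoro on a Shared Core: Expected Potency

A few compounds are considered here, and "the series" means these few. Any claim that something is new, unique, unknown or untested is made for them only; others in the source may bear on it.

Compound 1, `COc1ccc2cc(C(C)c3nnc4n3N=C(c3ccc(C)cc3)CS4)ccc2c1`: 8200 nM
Compound 2, `CC(C)Cc1ccc(C(C)c2nnc3n2N=C(c2ccc(F)cc2)CS3)cc1`: 7800 nM
Compound 3, `CC(c1ccc(-c2ccccc2)c(F)c1)c1nnc2n1N=C(c1ccc(Br)cc1)CS2`: 5000 nM

These three compounds share a core and were tested in a functional assay on Huh-7 cells (Homo sapiens) for inhibition, read by sulforhodamine B assay, with a stated time of 72 h; on this read-out higher numbers stand for weaker inhibition and lower numbers for stronger inhibition. Compound 2 gives the second highest number of the three, but its gaps to compound 1 and to compound 3 both lie within the usual scatter, so the three are not told apart by these numbers. Compound 4, `CC(C)Cc1ccc(C(C)c2nnc3n2N=C(c2ccc([N+](=O)[O-])cc2)CS3)cc1`, has not yet been measured. It differs from compound 2 by a single change: nitro in place of fluoro on an aromatic carbon. Among the measured compounds shown here, no two measured compounds differ in only one place, so no measured step shows what such a change does here. The step of a 1.1-fold lower number from compound 2 to compound 4 (0.05 log units; within the scatter) is therefore expected to stay within the scatter, in either direction. Compound 4 is estimated at 7000 nM, with a range from 3000 nM to 16000 nM.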

Compound 4, half-maximal inhibitory concentration: "not active" (no number reported)
The entry for compound 4 holds no number; there is nothing to compare the estimate with.
By their numbers in this assay, from the lowest: compounds 3, 2 and 1 (each within the scatter of the next).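

Among the compounds shown here, compound 4 is reported as "not active", without a number, in this assay, and no step from compound 2 to compound 4 can be read. Going by these compounds, how far nitro in place of fluoro shifts the number remains open. No evidence shown bears on this result.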